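The source may report more compounds than this note shows. Statements on the series, on what has been measured and on what is new or still open speak of the compounds shown alone.

Measured in a functional assay on MCF7 cells (Homo sapiens) for antiproliferative activity, read by MTT assay, with a stated time of 48 h; on this read-out lower numbers stand for stronger inhibition and higher numbers for weaker inhibition:
- compound 1 `CCCCCCCCn1cc(COC[C@@H]2OC[C@H](N)[C@@H]2O)nn1` gives 28100 nM
- compound 2 `CCCCCCCCCn1cc(COC[C@@H]2OC[C@H](N)[C@@H]2O)nn1` gives 12400 nM
- compound 3 `CCCCCCCCCCCCCCn1cc(COC[C@@H]2OC[C@H](N)[C@@H]2O)nn1` gives 1850 nM

Compound 3 holds the lowest number of the three in this assay, and its steps to both other compounds lie beyond the scatter. The next compound is compound 4 `CCCCCCCCCCCCCCCCCCn1cc(COC[C@@H]2OC[C@H](N)[C@@H]2O)nn1`, which differs from compound 3 by butyl in place of hydrogen on a saturated chain carbon, ten or more bonds along the chain from an aromatic nitrogen and so extends the same chain further.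

Within the data shown here, three measured steps bear on this change. All three extend the chain, and all three run toward lower numbers. The methyl step is modest at a 2.3-fold lower number from compound 1 to compound 2 (0.36 log units; beyond the scatter), the pentyl step is also modest at a 6.7-fold lower number from compound 2 to compound 3 (0.83 log units; beyond the scatter), and the hexyl step is large at a 15-fold lower number from compound 1 to compound 3 (1.18 log units; beyond the scatter). Among the measured compounds shown here, the trend rests on these three compounds alone, with no compound against it, and nothing measured shows whether it continues at this chain length.

A modest further step toward a lower number is therefore expected in this assay, smaller than the pentyl step, though a change within the scatter remains possible. The estimated step is a 2.3-fold lower number from compound 3 to compound 4 (0.36 log units; beyond the scatter) on this reasoning. For compound 4 the expected value is 800 nM with an estimated range from 250 nM to 3000 nM in this read-out.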

Compound 4, half-maximal inhibitory concentration: 7580 nM
Beside the measured number, compound 4's estimate is 9.5-fold (0.98 log units) below it, and the stated range ends below it.
By their numbers in this assay, from the lowest: compound 3; then compounds 4 and 2 (each within the scatter of the next); then compound 1.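

In this assay, lengthening the chain at this position no longer runs toward lower numbers: butyl in place of hydrogen gives a 4.1-fold higher number from compound 3 to compound 4 (0.61 log units; beyond the scatter), so compound 4 goes against the trend set by compounds 1, 2 and 3, and the response to chain length turns rather than running one way across the four compounds. The longest chain still reads differently from the shortest, with a 3.7-fold lower number from compound 1 to compound 4 (0.57 log units; beyond the scatter), whereas a 1.6-fold lower number from compound 2 to compound 4 (0.21 log units; within the scatter) places compound 4 and compound 2 within the scatter of each other despite their large difference in chain length. Nothing at hand accounts for the turn.

Still open, on these data alone, is where the turn lies, since chains of a length falling between those of compound 3 and compound 4 would show whether the lowest number sits at compound 3 or elsewhere in that span. Also open, as far as these compounds go, is how the same read-out responds to a chain ending in an amine or a carboxylic acid in place of the plain saturated chain.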